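The source may report more compounds than this note shows. Statements on the series, on what has been measured and on what is new or still open speak of the compounds shown alone.

In a functional assay on MCF7 cells (Homo sapiens) for antiproliferative activity, read by MTT assay, with a stated time of 96 h (on this read-out lower numbers stand for stronger inhibition and higher numbers for weaker inhibition), compound 1 `CSC(=S)N/N=C1\CC2(CCCCC2)Oc2c1ccc1ccccc21` gives 5100 nM, compound 2 `S=C(N/N=C1\CC2(CCCCC2)Oc2c1ccc1ccccc21)N1CCCCC1` gives 13400 nM and compound 3 `S=C(N/N=C1\CC2(CCCCC2)Oc2c1ccc1ccccc21)N1CCOCC1` gives 11900 nM. Compound 3 stands level with compound 2 within the scatter, and its number is higher than that of compound 1. Compound 4 `S=C(CN1CCCCC1)N/N=C1\CC2(CCCCC2)Oc2c1ccc1ccccc21` carries (piperidin-1-yl)methyl in place of morpholin-4-yl on a thiocarbonyl carbon. The relevant measured steps are a 2.6-fold higher number from compound 1 to compound 2 (0.42 log units; beyond the scatter) and a 2.3-fold higher number from compound 1 to compound 3 (0.37 log units; beyond the scatter), both modest, and a 1.1-fold lower number from compound 2 to compound 3 (0.05 log units; within the scatter), within the scatter. Among the compounds with values here, no measured compound carries (piperidin-1-yl)methyl, so the direction stays open and no step beyond the scatter is expected in this assay. The estimated step is a 1.1-fold lower number from compound 3 to compound 4 (0.03 log units; within the scatter). Compound 4 is estimated at 11000 nM, with an expected range of 4000 nM to 30000 nM.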

Compound 4, half-maximal inhibitory concentration: 11700 nM
The estimate for compound 4 lay 1.1-fold (0.03 log units) below the measured number; the measured number falls inside the stated range.
By their numbers in this assay, from the lowest: compound 1; then compounds 4, 3 and 2 (each within the scatter of the next).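

In this assay, (piperidin-1-yl)methyl on the thiocarbonyl carbon gives a 1.0-fold lower number from compound 3 to compound 4 (0.01 log units; within the scatter) and a 1.1-fold lower number from compound 2 to compound 4 (0.06 log units; within the scatter), so setting the piperidine ring off by a methylene leaves the number unchanged within the scatter. Methylsulfanyl remains apart, with a 2.3-fold higher number from compound 1 to compound 4 (0.36 log units; beyond the scatter), and all three ring-bearing groups now stand on the same side of compound 1. No evidence is available to explain this flat response.

On these data alone, whether ethylsulfanyl would stay level with methylsulfanyl remains open. So does the outcome for an open-chain dimethylamino group or a longer chain carrying the piperidine ring.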